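Swapping Propyl for Methoxy on the Chain Carbon

A few compounds are considered here, and "the series" means these few. Any claim that something is new, unique, unknown or untested is made for them only; others in the source may bear on it.

Compound 2, `CCCC/C(=C(/c1ccc(/C=C/C(=O)O)cc1)c1ccc2[nH]ncc2c1)c1ccccc1`, was tested in a functional assay on MCF7 cells (Homo sapiens) for cytotoxicity, read by CellTiter-Glo, with a stated time of 5 days (on this read-out lower numbers stand for stronger inhibition and higher numbers for weaker inhibition), and gives 10 nM. That is the lowest of the two numbers recorded so far. For the measured compounds named here, its only comparator is compound 1, `C/C(=C(/c1ccc(/C=C/C(=O)O)cc1)c1ccc2[nH]ncc2c1)c1ccccc1`, which in this assay gives 40 nM. Going by the values given here, the single change between those two is a 4.0-fold lower number from compound 1 to compound 2 (0.60 log units; beyond the scatter), so the longer chain went with the stronger inhibition.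

Compound 3, `COC/C(=C(/c1ccc(/C=C/C(=O)O)cc1)c1ccc2[nH]ncc2c1)c1ccccc1`, has not yet been measured in this assay. It differs from compound 2 in one place: methoxy in place of propyl on a saturated chain carbon bound to a double-bonded chain carbon. The new group is shorter than the propyl it replaces, so compound 3 sits between compound 1 and compound 2 in the length of that substituent. Among the compounds with values here, the only measured step that bears on this change is a 4.0-fold lower number from compound 1 to compound 2 (0.60 log units; beyond the scatter), a modest one. A partial reversal of it is therefore expected: a somewhat higher number, probably beyond the scatter but smaller than that step. For compound 3 the estimated result is 25 nM, with a range from 8 nM to 80 nM, which amounts to an expected step of a 2.5-fold higher number from compound 2 to compound 3 (0.40 log units; beyond the scatter).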

Compound 3, half-maximal inhibitory concentration: 88 nM
For compound 3 the middle estimate is 3.5-fold (0.55 log units) below the measured one; the whole stated range lies below it.
By their numbers in this assay, from the lowest: compound 2; then compound 1; then compound 3.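

In this assay, the methoxy change does not place compound 3 in the middle of the series: there is an 8.8-fold higher number from compound 2 to compound 3 (0.94 log units; beyond the scatter), and also a 2.2-fold higher number from compound 1 to compound 3 (0.34 log units; beyond the scatter), so compound 3 gives the highest number of the three. On a saturated chain carbon bound to a double-bonded chain carbon, then, the size of the group alone does not set the order, and compound 3 goes against the link between a longer chain and stronger inhibition that compounds 1 and 2 suggested: its methoxymethyl chain is longer than the methyl of compound 1, yet it goes with weaker inhibition. Nothing measured here explains why this swap costs more than the chain length would suggest.

These three compounds leave open whether the loss follows the oxygen itself or some other difference between the butyl and methoxymethyl chains, and an all-carbon propyl chain of matching length would help separate the two. From the compounds shown here alone, it also remains open whether a pentyl chain would lower the number further, and how a chain carrying an amine or a hydroxyl would behave at this position.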